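Ether Chain Variation on a Shared Core

The compounds below may be only part of what the source reports. "The series", "measured", "known", "first", "only" and "open" are said of these compounds alone.

Two compounds have been measured in an assay on cells with melanin-concentrating hormone receptor 1 (Homo sapiens) as the target, read by radioligand binding; on this read-out higher numbers stand for weaker inhibition and lower numbers for stronger inhibition:

compound 1 `COC(C)(C)CCOc1cccc2ccc(N)nc12`: 132 nM
compound 2 `Nc1ccc2cccc(OCC3CC3)c2n1`: > 2000 nM

Compound 2 stands at the weak end of what has been measured. The value shown for compound 2 is a limit of this assay and not a number, as noted by the limit of > 2000 nM in this assay, at which 1 of the 2 values shown sits. Among the compounds with values here, the single measured step, an at least 15-fold higher number from compound 1 to compound 2 (1.18 log units; beyond the scatter), shows that shortening the chain on the saturated chain carbon bound to an oxygen on the aromatic ring to a cyclopropyl costs a large amount of binding.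

Compound 3 `CSCCOc1cccc2ccc(N)nc12` carries the change ((methylsulfanyl)methyl in place of cyclopropyl on a saturated chain carbon bound to an oxygen on an aromatic ring). This moves back toward a heteroatom-bearing chain, though shorter than that of compound 1, so the measured step from compound 1 to compound 2 bears on it only in reverse and in part. A recovery of some of the loss seen in an at least 15-fold higher number from compound 1 to compound 2 (1.18 log units; beyond the scatter) is therefore expected, while a value still weaker than compound 1 remains plausible. For compound 3 the expected value in this assay is 500 nM, within 150 nM to 2000 nM, an expected step of an at least 4.0-fold lower number from compound 2 to compound 3 (0.60 log units; beyond the scatter).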

Compound 3, half-maximal inhibitory concentration: > 2000 nM
Compound 3: a limit, no number (the forecaster's own chance of this, stated with the estimate: 30%); middle value at least 4.0-fold (0.60 log units) away from the limit.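

In this assay, compound 3 gives > 2000 nM, which is a limit of the assay and not a number. Placing methylsulfanyl where compound 1 carries 1-methoxy-1-methylethyl, on a saturated chain carbon, two bonds along the chain from an oxygen on an aromatic ring, gives an at least 15-fold higher number from compound 1 to compound 3 (1.18 log units; beyond the scatter), so a sulfur-bearing chain on the shared core does not keep the binding seen with compound 1, and the loss with compound 2 is not specific to a cyclopropyl ring. The step from compound 2 to compound 3 cannot be read, and cyclopropyl and (methylsulfanyl)methyl cannot be ranked against each other, because of where the values sit: the limit of > 2000 nM in this assay, at which 2 of the 3 values shown sit.

As far as these compounds go, of the three compounds, only compound 1 gives a number, so it stays open whether its binding depends on the methoxy group, on the two methyl branches or on the overall length of its chain. A chain that keeps the branched carbon but ends in a hydroxyl group, or one that ends in an amine, could begin to separate these possibilities.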